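A few compounds are considered here, and "the series" means these few. Any claim that something is new, unique, unknown or untested is made for them only; others in the source may bear on it.

In a functional assay on SK-BR-3 cells (Homo sapiens) for cytotoxicity, read by MTT assay, with a stated time of 72 h (on this read-out lower numbers stand for stronger inhibition and higher numbers for weaker inhibition), compound 1 `Nc1cccc(Nc2c(C(=O)NCc3ccc(F)cc3)nc(Br)c3cccnc23)c1` gives > 10000 nM, which is a limit of the assay and not a number. For the measured compounds named here, compound 2 `Nc1ccc(Nc2c(C(=O)NCc3ccc(F)cc3)nc(Br)c3cccnc23)cc1` gives 4000 nM, the only true number so far. Compound 3 `CN(C)CCCNc1c(C(=O)NCc2ccc(F)cc2)nc(Br)c2cccnc12` differs from it as follows: 3-(dimethylamino)propyl in place of 4-aminophenyl on a nitrogen on an aromatic ring. In words, this is 3-(dimethylamino)propyl in place of 4-aminophenyl on a nitrogen on an aromatic ring. Going by the values given here, only one measured step bears on this change, an at least 2.5-fold lower number from compound 1 to compound 2 (0.39 log units; beyond the scatter), and it rests on (the limit of > 10000 nM in this assay, at which 1 of the 2 values shown sits). That step exchanged one aminophenyl group for another at the same nitrogen, so it shows that this substituent can shift the read-out, but it gives no size for removing the ring altogether. No clear direction can be drawn from it, and the expected change in this assay stays modest and uncertain. The estimated step is a 1.3-fold lower number from compound 2 to compound 3 (0.12 log units; within the scatter). For compound 3 the expected value is 3000 nM, within an estimated range from 700 nM to 10000 nM.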

Compound 3, half-maximal inhibitory concentration: 1000 nM
For compound 3 the middle estimate is 3.0-fold (0.48 log units) above the measured one; low and high end bracket the measured number.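

In this assay, for the compounds shown here, the earlier compounds compared only two aminophenyl groups on this nitrogen, whereas 3-(dimethylamino)propyl, which has no ring, gives a 4.0-fold lower number from compound 2 to compound 3 (0.60 log units; beyond the scatter). So at this position on the shared core, an aromatic ring on the nitrogen is not required for the read-out in this cell assay, and compound 3 gives a lower number than either aminophenyl compound. The comparison with the other aminophenyl group gives an at least 10-fold lower number from compound 1 to compound 3 (1.00 log units; beyond the scatter), but this size is only a bound: the limit of > 10000 nM in this assay, at which 1 of the 3 values shown sits.

With only one chain shown, the compounds do not separate the loss of the ring from the arrival of the dimethylamino group. Going by these compounds, whether a plain propyl chain, a shorter or longer chain ending in dimethylamino, or a morpholine at the chain end would keep this gain remains open.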